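The compounds below may be only part of what the source reports. "The series", "measured", "known", "first", "only" and "open" are said of these compounds alone.

Compound 2 `O=C(Nc1c(C(O)(C(F)(F)F)C(F)(F)F)ccc2ccccc12)C1CCCC1` gives 495 nM in an assay on LtK cells with ATP-sensitive inward rectifier potassium channel 11 (Homo sapiens) as the target; a lower number here means that less compound is needed, a higher number that more compound is needed for the effect. Among the three measured members of this series it holds the second highest number: compound 1 `C/C=C/C(=O)Nc1c(C(O)(C(F)(F)F)C(F)(F)F)ccc2ccccc12` gives 72 nM, and compound 3 `Cc1ccccc1C(=O)Nc1c(C(O)(C(F)(F)F)C(F)(F)F)ccc2ccccc12` gives 5550 nM. The steps between them are all beyond the scatter: a 6.9-fold higher number from compound 1 to compound 2 (0.84 log units; beyond the scatter), a 77-fold higher number from compound 1 to compound 3 (1.89 log units; beyond the scatter) and an 11-fold higher number from compound 2 to compound 3 (1.05 log units; beyond the scatter).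

Compound 4 `O=C(Nc1c(C(O)(C(F)(F)F)C(F)(F)F)ccc2ccccc12)c1ccc(Cl)cc1` has not yet been measured in this assay. It differs from compound 2 in one place: 4-chlorophenyl in place of cyclopentyl on a carbonyl carbon. Within the data shown here, the step that bears most directly on this change is the one from compound 2 to compound 3, where a 2-methylphenyl also replaced cyclopentyl on the carbonyl carbon and the number rose sharply, an 11-fold higher number from compound 2 to compound 3 (1.05 log units; beyond the scatter). That step involves a different aromatic substituent, so the size it suggests is only a guide, but it points in one direction. Compound 4 is therefore expected to show a higher number than compound 2, with a 5.1-fold higher number from compound 2 to compound 4 (0.70 log units; beyond the scatter) as the expected step. For compound 4 the estimate in this assay is 2500 nM, within a range of 700 nM to 8000 nM.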

Compound 4, half-maximal effective concentration: 570 nM
Compound 4: middle estimate off by 4.4-fold (0.64 log units), on the high side; measured number below the stated range.
By their numbers in this assay, from the lowest: compound 1; then compounds 2 and 4 (each within the scatter of the next); then compound 3.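

In this assay an aromatic ring on the carbonyl carbon does not by itself set the number apart from cyclopentyl: a 1.2-fold higher number from compound 2 to compound 4 (0.06 log units; within the scatter) is the step for 4-chlorophenyl in place of cyclopentyl, so these two groups cannot be told apart here. The high number of compound 3 therefore does not extend to every substituted phenyl at this place, as a 9.7-fold lower number from compound 3 to compound 4 (0.99 log units; beyond the scatter) shows for 4-chlorophenyl in place of 2-methylphenyl. The new result also leaves prop-1-en-1-yl as the only group shown with a number lower than all the others beyond the scatter, with a 7.9-fold higher number from compound 1 to compound 4 (0.90 log units; beyond the scatter) as the step to 4-chlorophenyl.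

Since 4-chlorophenyl and 2-methylphenyl differ in both the substituent and its place on the ring, the compounds shown cannot say which of the two goes with the gap between them, and how a plain phenyl, a longer chain or an amine would behave on this carbonyl carbon remains open. No measurement at hand offers an explanation for any of these steps.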